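Replacing the pyridinyl ethenyl arm with tert-butylphenyl

A few compounds are considered here, and "the series" means these few. Any claim that something is new, unique, unknown or untested is made for them only; others in the source may bear on it.

Compound 1 `COC(=O)/C=C/c1cccc(N(Cc2ccc(/C=C/c3ccccn3)cc2)C(=O)C2CCCCC2)c1` was tested in an assay on isolated protein with Bile acid receptor (Homo sapiens) as the target (on this read-out higher numbers stand for an effect only at larger amounts of compound and lower numbers for an effect already at smaller amounts), and compound 1 gives 309 nM there. Among the three measured compounds it sits in the middle of a narrow spread: compound 2 `COC(=O)/C=C/c1cccc(N(Cc2ccc(/C=C/c3ccccn3)cc2)C(=O)C(C)C)c1` gives 310 nM in this assay, and compound 3 `COC(=O)/C=C/c1cccc(N(Cc2ccc(-c3ccc(OC(F)(F)F)cc3)cc2)C(=O)C(C)C)c1` gives 219 nM, so all three lie within the scatter of each other. The step with isopropyl in place of cyclohexyl on a carbonyl carbon gave a 1.0-fold higher number from compound 1 to compound 2 (0.00 log units; within the scatter), and the step with 4-(trifluoromethoxy)phenyl in place of 2-(pyridin-2-yl)ethenyl on an aromatic carbon gave a 1.4-fold lower number from compound 2 to compound 3 (0.15 log units; within the scatter).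

Compound 4 `COC(=O)/C=C/c1cccc(N(Cc2ccc(-c3ccc(C(C)(C)C)cc3)cc2)C(=O)C2CCCCC2)c1` differs from compound 1 in one place: 4-(tert-butyl)phenyl in place of 2-(pyridin-2-yl)ethenyl on an aromatic carbon. Going by the values given here, the change most like it is the one from compound 2 to compound 3, which also put a para-substituted phenyl in place of the 2-(pyridin-2-yl)ethenyl group and stayed within the scatter. No step beyond the scatter is therefore expected, and the estimated change is a 1.2-fold lower number from compound 1 to compound 4 (0.09 log units; within the scatter). Compound 4 is expected to give about 250 nM in this assay, between 100 nM and 600 nM.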

Compound 4, half-maximal effective concentration: 132 nM
Compound 4: middle estimate off by 1.9-fold (0.28 log units), on the high side, within the range that was stated.
By their numbers in this assay, from the lowest: compounds 4, 3, 1 and 2 (each within the scatter of the next, the first and the last beyond it).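

In this assay, the exchange at this aromatic carbon now produces a step beyond the scatter: 4-(tert-butyl)phenyl in place of 2-(pyridin-2-yl)ethenyl gave a 2.3-fold lower number from compound 1 to compound 4 (0.37 log units; beyond the scatter) with cyclohexyl on the carbonyl. The earlier exchange at the same place, with isopropyl on the carbonyl and 4-(trifluoromethoxy)phenyl entering, gave a 1.4-fold lower number from compound 2 to compound 3 (0.15 log units; within the scatter) and so did not show that the read-out can respond to a change here. No measurement bears on what lies behind this modest step.

The compounds shown leave open how much of the step belongs to the tert-butyl group itself, which an unsubstituted phenyl at this place would help to separate. They also leave open whether 4-(tert-butyl)phenyl gives a similar step with isopropyl on the carbonyl.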